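Chloro to bromo swap across two cores

A few compounds are considered here, and "the series" means these few. Any claim that something is new, unique, unknown or untested is made for them only; others in the source may bear on it.

Compound 1 `N=C(N)Nc1cccc(C(=O)NNC(=O)NC(CC(=O)O)c2ccc(Cl)cc2)c1` and compound 2 `N=C(N)Nc1cccc(C(=O)NNC(=O)NC(CC(=O)O)c2ccc(Br)cc2)c1` share one core. In a physicochemical assay for lipophilicity (a lower number here means a more polar compound, a higher number a more lipophilic compound), compound 1 gives 1.26 and compound 2 gives 1.53. The change between them, (bromo in place of chloro on an aromatic carbon), made a step of a number 0.27 log units higher from compound 1 to compound 2 (within the scatter). Compound 3 `O=C(O)CC(NC(=O)NNC(=O)CCCCNc1ccccn1)c1ccc(Cl)cc1` is built on a different core; the difference between the two cores is not broken down here. In this assay compound 3 gives 2.2, the highest of the three numbers. Compound 4 `O=C(O)CC(NC(=O)NNC(=O)CCCCNc1ccccn1)c1ccc(Br)cc1` carries the same change on the core of compound 3: bromo in place of chloro on an aromatic carbon. The two place descriptions match word for word. Going by the values given here, for compound 4 the step of a number 0.27 log units higher from compound 3 to compound 4 (within the scatter) is expected to resemble the earlier one, because a number 0.27 log units higher from compound 1 to compound 2 (within the scatter) is the only example of this change that has a measured number. Compound 4 is therefore estimated at 2.47, between 2.1 and 2.85.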

Compound 4, partition coefficient: 2.47
Beside the measured number, compound 4's estimate shows no gap at the digits printed; low and high end bracket the measured number.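

In this assay the swap of chloro for bromo gives a number 0.27 log units higher from compound 3 to compound 4 (within the scatter) and so matches in size the earlier step, a number 0.27 log units higher from compound 1 to compound 2 (within the scatter) on the other core. The change therefore carries over between these two cores with a step of the same size, but both steps lie within the scatter, so neither pair separates 4-chlorophenyl from 4-bromophenyl, and two pairs set no rule for the series. No available evidence bears on why the two steps agree.

On these data alone, whether the agreement holds for fluoro, methyl or trifluoromethyl on the same aromatic carbon remains open. Also open, as far as these compounds go, is how the same swap behaves on a core with a longer chain or without the carboxylic acid.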